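A few compounds are considered here, and "the series" means these few. Any claim that something is new, unique, unknown or untested is made for them only; others in the source may bear on it.

Measured in a functional assay on U-251 cells (Homo sapiens) for inhibition, read by spectrophotometry and sulforhodamine B assay, with a stated time of 48 h; a lower number here means a stronger inhibitor of growth, a higher number a weaker inhibitor of growth:
- compound 1 `Cc1ccc(N2C(=O)CS/C2=N/N=C/c2c[nH]c3ccc(Br)cc23)cc1`: 54700 nM
- compound 2 `S=C(N/N=C/c1c[nH]c2ccc(Br)cc12)Nc1cccc2ccccc12`: 7320 nM

Compound 2 holds the lower of the two numbers, at 7320 nM, and compound 1 stands higher, at 54700 nM, a gap beyond the usual scatter. The two differ in more than one place, so this gap says nothing about any single group.

The next compound is compound 3 `S=C(N/N=C/c1c[nH]c2ccccc12)Nc1cccc2ccccc12`. It carries hydrogen in place of bromo on an aromatic carbon, and the rest of compound 2 is unchanged. For the measured compounds named here, no measured pair isolates this change, so the direction is a weak expectation. A modest loss of growth inhibition in this assay is expected, possibly not beyond the scatter. The expected change is a 1.6-fold higher number from compound 2 to compound 3 (0.21 log units; within the scatter). For compound 3 the estimated value is 12000 nM, with an expected range from 4000 nM to 35000 nM.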

Compound 3, concentration for 50% growth inhibition: 920 nM
Beside the measured number, compound 3's estimate is 13-fold (1.12 log units) above it, and the stated range ends above it.
By their numbers in this assay, from the lowest: compound 3; then compound 2; then compound 1.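

In this assay, for the compounds shown here, hydrogen in place of bromo on an aromatic carbon gives an 8.0-fold lower number from compound 2 to compound 3 (0.90 log units; beyond the scatter) and this is the first step that isolates a single position. The position is therefore not silent in this assay: with the rest of the structure unchanged, the compound without the bromo is the stronger inhibitor of growth of this pair. This rests on one pair only, and compound 1 differs from both in more than one place, so nothing can be said of the same change on its core. No measurement shown accounts for the size or direction of this step.

From the compounds shown here alone, whether a chloro, a methoxy or an amine on the same aromatic carbon would give a number nearer compound 3 or compound 2 stays open. Also open, going by these compounds, is whether the same exchange would move the number in the same direction on the core of compound 1.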